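Para-substituent swap on the anilide of the nitrobenzofurazan thioether series

The compounds below may be only part of what the source reports. "The series", "measured", "known", "first", "only" and "open" are said of these compounds alone.

For the measured compounds named here, compound 2 `O=C(CCC(=O)OCCCCCCSc1ccc([N+](=O)[O-])c2nonc12)Nc1ccc(F)cc1` is one of two compounds measured in an assay on isolated protein for inhibition of glutathione S-transferase P (Homo sapiens), with a stated time of 10 min; a higher number here means a weaker inhibitor, a lower number a stronger inhibitor. In this assay, going by the values given here, compound 2 gives 8570 nM, and the only neighbour, compound 1 `O=C(CCC(=O)OCCCCCCSc1ccc([N+](=O)[O-])c2nonc12)Nc1ccccc1Cl`, gives 15500 nM. The step of a 1.8-fold lower number from compound 1 to compound 2 (0.26 log units; within the scatter) is within the scatter, so the two numbers cannot be ordered.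

Compound 3 `Cc1ccc(NC(=O)CCC(=O)OCCCCCCSc2ccc([N+](=O)[O-])c3nonc23)cc1` differs from compound 2 by methyl in place of fluoro on an aromatic carbon. Among the compounds with values here, no measured step exchanges one para substituent for another; the single step known, the one from compound 1 to compound 2, swaps one substituted phenyl for another and stays within the scatter. On that basis no shift beyond the scatter is expected in this assay for compound 3 in either direction, and the expected step is a 1.0-fold lower number from compound 2 to compound 3 (0.00 log units; within the scatter). Compound 3 is therefore estimated at 8500 nM, with a range from 3000 nM to 22000 nM.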

Compound 3, half-maximal inhibitory concentration: 6800 nM
Beside the measured number, compound 3's estimate is 1.3-fold (0.10 log units) above it, within the range that was stated.
By their numbers in this assay, from the lowest: compounds 3, 2 and 1 (each within the scatter of the next, the first and the last beyond it).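

The exchange of fluoro for methyl on the aromatic carbon para to a large group gives a 1.3-fold lower number from compound 2 to compound 3 (0.10 log units; within the scatter), so in this assay these two groups cannot be ordered at this position. The step of a 2.3-fold lower number from compound 1 to compound 3 (0.36 log units; beyond the scatter) is the only modest change beyond the scatter among the listed pairs, but 4-methylphenyl in place of 2-chlorophenyl alters both the substituent and where it sits, so the shift cannot be assigned to either alone. Nothing available gives a reason for either step.

From the compounds shown here alone, whether a chloro group at this same position would separate the identity of the substituent from its placement stays open. Also open, going by these compounds, is whether an amine or a carboxylic acid here would move the number beyond the scatter in either direction.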